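A new phenyl group on the amide nitrogen

The compounds below may be only part of what the source reports. "The series", "measured", "known", "first", "only" and "open" are said of these compounds alone.

Measured in an in vitro ADME assay on microsomes from liver (Homo sapiens) for pharmacokinetics, read by LC-MS, with a stated time of 10 min, tested at 1 uM; a higher number here means faster removal of the compound, a lower number slower removal:
- compound 1 `Cc1cccc(NC(=O)[C@H]2CN(C)C[C@@H]2c2ccc(/C=C/C(=O)Nc3ccccc3N)cc2)c1` gives 14 mL/min/kg
- compound 2 `CN1C[C@H](C(=O)Nc2ccc(F)c(Br)c2)[C@@H](c2ccc(/C=C/C(=O)Nc3ccccc3N)cc2)C1` gives 15 mL/min/kg
- compound 3 `Cc1cc(NC(=O)[C@H]2CN(C)C[C@@H]2c2ccc(/C=C/C(=O)Nc3ccccc3N)cc2)ccc1Cl` gives 15 mL/min/kg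

Compound 3 matches compound 2 at the digits shown and lies within the scatter of compound 1. The next structure, compound 4 `CN1C[C@H](C(=O)Nc2ccc(Cl)cc2F)[C@@H](c2ccc(/C=C/C(=O)Nc3ccccc3N)cc2)C1`, differs from compound 3 as follows: 4-chloro-2-fluorophenyl in place of 4-chloro-3-methylphenyl on an amide-type nitrogen. In words, 4-chloro-2-fluorophenyl stands in place of 4-chloro-3-methylphenyl on an amide-type nitrogen.

Among the compounds with values here, three measured steps bear on this change, since each alters the phenyl group at that same place. They are a 1.1-fold higher number from compound 1 to compound 2 (0.03 log units; within the scatter), a 1.1-fold higher number from compound 1 to compound 3 (0.03 log units; within the scatter) and no change at the digits printed from compound 2 to compound 3 (within the scatter). All three stay within the scatter. Within the data shown here, none of the measured compounds carries the 4-chloro-2-fluorophenyl group, so the comparison rests on these few neighbours alone. No step beyond the scatter is therefore expected in this assay. The expected change is a 1.1-fold lower number from compound 3 to compound 4 (0.03 log units; within the scatter). For compound 4 the estimated clearance is 14 mL/min/kg, with an expected range from 8 mL/min/kg to 24 mL/min/kg.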

Compound 4, clearance: 11 mL/min/kg
Compound 4: middle estimate off by 1.3-fold (0.10 log units), on the high side, within the range that was stated.
By their numbers in this assay, from the lowest: compounds 4, 1, 2 and 3 (each within the scatter of the next).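

Setting 4-chloro-2-fluorophenyl on the amide-type nitrogen in place of 4-chloro-3-methylphenyl gives the largest step yet seen at this position (a 1.4-fold lower number from compound 3 to compound 4 (0.13 log units; within the scatter)), and the comparisons with the other two phenyl groups read much the same (a 1.4-fold lower number from compound 2 to compound 4 (0.13 log units; within the scatter); a 1.3-fold lower number from compound 1 to compound 4 (0.10 log units; within the scatter)). All three remain within the scatter, so a fourth phenyl group on this nitrogen still produces no step beyond it in this assay. Nothing measured here offers a reason for these small differences.

The phenyl groups shown carry only chloro, bromo, fluoro or methyl. Going by these compounds, whether a carboxylic acid or an aminomethyl group on that ring, or a cyclohexyl group in its place, would produce a step beyond the scatter remains open.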